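Bromo for fluoro on the sulfonyl aryl group

The source may hold more compounds than are shown below. What is called first, only, known or untested is meant among the compounds shown, and "the series" means these compounds.

In a functional assay on A549 cells (Homo sapiens) for antiproliferative activity, read by MTT assay, with a stated time of 24 h (on this read-out lower numbers stand for stronger inhibition and higher numbers for weaker inhibition), compound 1 `Cc1ccc(-c2nn(-c3ccccc3)cc2-c2nc3ccccc3[nH]2)cc1` gives 4010 nM and compound 2 `Cc1ccc(-c2nn(-c3ccccc3)cc2-c2nc3ccccc3n2S(=O)(=O)c2cc(C)ccc2C)cc1` gives 270 nM while compound 3 `Cc1ccc(-c2nn(-c3ccccc3)cc2-c2nc3ccccc3n2S(=O)(=O)c2ccc(F)cc2)cc1` gives 3240 nM on the same read-out. Two steps place compound 3: a 1.2-fold lower number from compound 1 to compound 3 (0.09 log units; within the scatter) stays within the scatter and a 12-fold higher number from compound 2 to compound 3 (1.08 log units; beyond the scatter) is large. Compound 4 `Cc1ccc(-c2nn(-c3ccccc3)cc2-c2nc3ccccc3n2S(=O)(=O)c2ccc(Br)cc2)cc1` differs from compound 3 at one place (bromo in place of fluoro on an aromatic carbon): bromo in place of fluoro on an aromatic carbon, para to a large group. Going by the values given here, no measured step covers this exchange. The aryl group on the sulfonyl can still matter, as the large step shows (a 15-fold lower number from compound 1 to compound 2 (1.17 log units; beyond the scatter)), so the expected range stays wide. No step beyond the scatter is expected (a 1.6-fold lower number from compound 3 to compound 4 (0.21 log units; within the scatter)). For compound 4 the estimated value is 2000 nM with a range from 600 nM to 5500 nM in this assay.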

Compound 4, half-maximal inhibitory concentration: 1860 nM
For compound 4 the middle estimate is 1.1-fold (0.03 log units) above the measured one, and the stated range covers the measured number.
By their numbers in this assay, from the lowest: compound 2; then compounds 4, 3 and 1 (each within the scatter of the next, the first and the last beyond it).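

In this assay the exchange of fluoro for bromo on the sulfonyl aryl group stays within the scatter (a 1.7-fold lower number from compound 3 to compound 4 (0.24 log units; within the scatter)). The (4-bromophenyl)sulfonyl group nevertheless lies modestly beyond the scatter from the unsubstituted nitrogen (a 2.2-fold lower number from compound 1 to compound 4 (0.33 log units; beyond the scatter)), whereas 2,5-dimethylphenyl on the sulfonyl sulfur still gives the lower number (a 6.9-fold higher number from compound 2 to compound 4 (0.84 log units; beyond the scatter)). No available evidence bears on these differences.

The compounds shown leave open whether one methyl group on the sulfonyl aryl ring would match 2,5-dimethylphenyl. As far as these compounds go, how an amine or a carboxylic acid on that ring would read also remains open.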